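Swapping bromo for cyano on a metabolically stable core

The source may report more compounds than this note shows. Statements on the series, on what has been measured and on what is new or still open speak of the compounds shown alone.

Compound 1 `Cc1nc(N)nc2c1c(-c1ccc3oc(N)nc3c1)nn2C(C)C` sits at a limit in an ADME assay on microsomes from liver (Homo sapiens) for metabolic stability, read by LC-MS, with a stated time of 15 min, tested at 1 uM, in the presence of a further agent that is not named here; on this read-out higher numbers stand for a more stable compound and lower numbers for a less stable compound: compound 1 gives > 95%.
Compound 2 `COc1nc(N)nc2c1c(-c1ccc3oc(N)nc3c1)nn2C(C)C` also sits at a limit; compound 2 gives > 95%.
Among the measured compounds shown here, compound 3 `CC(C)n1nc(-c2ccc3oc(N)nc3c2)c2c(Br)nc(N)nc21` gives 94%, the only plain number among the three.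

Two of the three readings are thus (the limit of > 95% in this assay, at which 2 of the 3 values shown sit), so compound 3 stands as the single measured point, and the steps of a number at least 1 percentage points lower from compound 1 to compound 3 (that floor lies within the scatter) and a number at least 1 percentage points lower from compound 2 to compound 3 (that floor lies within the scatter) are both small. Compound 4 `CC(C)n1nc(-c2ccc3oc(N)nc3c2)c2c(C#N)nc(N)nc21` differs from compound 3 in one place: cyano in place of bromo on an aromatic carbon. For the measured compounds named here, no measured step changes this position in the same way, and the steps that do touch it stay within the scatter. Compound 4 is therefore expected to remain about as stable as compound 3, with a number 1 percentage points lower from compound 3 to compound 4 (within the scatter) expected. The estimate for compound 4 is 93%, expected to lie between 84% and 99%.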

Compound 4, percent of the compound remaining: > 95%
Compound 4 gave a limit, no number (the forecaster's own chance of this, stated with the estimate: 40%); at least 2 percentage points between middle value and limit.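

Putting cyano in place of bromo on this aromatic carbon gives a number at least 1 percentage points higher from compound 3 to compound 4 (that floor lies within the scatter), so in this assay this position accepts a nitrile with no loss that can be seen, just as it accepts methyl, methoxy and bromo. The steps to compound 4 from compound 1 and compound 2 cannot be read, because all three compounds sit at the same limit: the limit of > 95% in this assay, at which 3 of the 4 values shown sit.

The compounds shown therefore do not rank these groups against one another. Going by these compounds, whether a carboxylic acid or a longer chain on this carbon would bring the number down stays open.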